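The source may report more compounds than this note shows. Statements on the series, on what has been measured and on what is new or still open speak of the compounds shown alone.

Measured so far in a functional assay on COLO 205 cells (Homo sapiens) for cytotoxicity, read by MTT assay, with a stated time of 72 h; on this read-out higher numbers stand for weaker inhibition and lower numbers for stronger inhibition: compound 1 `COc1cccc(/C=C/C(=O)Nc2cc(C(=O)c3cc(OC)c(OC)c(OC)c3)ccc2OC)c1` with 5100 nM, and compound 2 `COc1cccc(/C=C/C(=O)Nc2cc(C(=O)c3cc(OC)c(OC)c(OC)c3)cc(OC)c2OC)c1` with 10700 nM.

Among the measured compounds shown here, compound 2 gives the highest of the two numbers; its nearest neighbour is compound 1, and the only single-point step recorded runs a 2.1-fold higher number from compound 1 to compound 2 (0.32 log units; beyond the scatter), a methoxy in place of hydrogen on an aromatic carbon of the shared core.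

Compound 3 `COc1cc(C(=O)c2cc(OC)c(OC)c(OC)c2)cc(NC(=O)/C=C/c2ccc(C(F)(F)F)cc2)c1OC` departs from compound 2 at the other end of the molecule: 4-(trifluoromethyl)phenyl in place of 3-methoxyphenyl on a double-bonded chain carbon bound to a double-bonded chain carbon, on a double-bonded chain carbon bound to a double-bonded chain carbon. For the measured compounds named here, no measured step touches this part of the structure; the one step known, from compound 1 to compound 2, concerns the aromatic core and says nothing about the aryl group on the chain. Going by the values given here, there is therefore no basis from these compounds to expect a step in this assay in either direction beyond the scatter, and the uncertainty is wide.

Compound 3 is estimated at 10000 nM, within a range of 3000 nM to 35000 nM, which means an expected step of a 1.1-fold lower number from compound 2 to compound 3 (0.03 log units; within the scatter).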

Compound 3, half-maximal inhibitory concentration: 2500 nM
Compound 3: the middle estimate sits 4.0-fold (0.60 log units) above what was measured; measured number below the stated range.
By their numbers in this assay, from the lowest: compound 3; then compound 1; then compound 2.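

In this assay, the aryl group on the chain proves to be a place where the number can move, as 4-(trifluoromethyl)phenyl in place of 3-methoxyphenyl on a double-bonded chain carbon bound to a double-bonded chain carbon gives a 4.3-fold lower number from compound 2 to compound 3 (0.63 log units; beyond the scatter) and so points to stronger inhibition. Among the compounds shown here, the only earlier step, a 2.1-fold higher number from compound 1 to compound 2 (0.32 log units; beyond the scatter), came from a methoxy on the shared core and pointed to weaker inhibition, so these two single changes, made in different parts of the molecule, run in opposite directions. Nothing at hand accounts for the gain, and this one exchange replaces both the substituent and its ring position, so the step cannot be assigned to either alone.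

On these data alone, it remains open whether the lower number follows the trifluoromethyl group or its position, a question that 3-(trifluoromethyl)phenyl and 4-methoxyphenyl at this place would help to separate. Also open, as far as these compounds go, are whether a 4-chlorophenyl or a 4-(dimethylamino)phenyl group would move the number in the same direction, and whether 4-(trifluoromethyl)phenyl would give a similar step on the core of compound 1.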